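From 4-fluorobenzyl to 4-bromobenzyl: a small expected step

The source may hold more compounds than are shown below. What is called first, only, known or untested is meant among the compounds shown, and "the series" means these compounds.

Compound 1 `CN(Cc1ccccc1)C(=O)c1cc2c(Cc3ccccc3)n[nH]c2cc1O`: 980 nM
Compound 2 `CN(Cc1ccccc1F)C(=O)c1cc2c(Cc3ccccc3)n[nH]c2cc1O`: 1500 nM
Compound 3 `CN(Cc1ccc(F)cc1)C(=O)c1cc2c(Cc3ccccc3)n[nH]c2cc1O`: 4100 nM

These values come from a functional assay on A2780 cells (Homo sapiens) for antiproliferative activity, read by resazurin assay, with a stated time of 72 h; a higher number here means a weaker inhibitor, a lower number a stronger inhibitor. Compound 3 has the highest number of the three at 4100 nM, which makes it the weakest inhibitor in this small set.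

Compound 4 `CN(Cc1ccc(Br)cc1)C(=O)c1cc2c(Cc3ccccc3)n[nH]c2cc1O` differs from compound 3 by a single change, bromo in place of fluoro on an aromatic carbon. Among the compounds with values here, no measured step makes this swap. The nearest evidence concerns fluoro alone: one placement gave a 1.5-fold higher number from compound 1 to compound 2 (0.18 log units; within the scatter), another gave a 4.2-fold higher number from compound 1 to compound 3 (0.62 log units; beyond the scatter), and moving it gave a 2.7-fold higher number from compound 2 to compound 3 (0.44 log units; beyond the scatter). These steps are modest at most, and none of them shows what bromo does. No step beyond the scatter is therefore expected in this assay, and no direction can be favoured with confidence. The estimated change is a 1.2-fold lower number from compound 3 to compound 4 (0.07 log units; within the scatter). The expected value for compound 4 is 3500 nM, with an estimated range of 1100 nM to 11000 nM.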

Compound 4, half-maximal inhibitory concentration: 2800 nM
Compound 4: middle estimate off by 1.3-fold (0.10 log units), on the high side; low and high end bracket the measured number.
By their numbers in this assay, from the lowest: compounds 1, 2, 4 and 3 (each within the scatter of the next, the first and the last beyond it).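

In this assay, replacing fluoro with bromo on the 4-substituted benzyl group gives a 1.5-fold lower number from compound 3 to compound 4 (0.17 log units; within the scatter), so the two halogens cannot be told apart at this position. Compound 4 also stays within the scatter of the 2-fluorophenyl compound, with a 1.9-fold higher number from compound 2 to compound 4 (0.27 log units; within the scatter), yet bromo in place of hydrogen gives a 2.9-fold higher number from compound 1 to compound 4 (0.46 log units; beyond the scatter), so at this position both fluoro in compound 3 and bromo in compound 4 stand apart from the unsubstituted benzyl group, while fluoro at the other position in compound 2 does not. Nothing measured here accounts for these numbers.

The compounds shown leave open how chloro would compare with fluoro and bromo at this position. They also leave open what a group of a different kind, such as methoxy, an amine or a carboxylic acid, would do there.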